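Methoxy in place of fluoro: an expected flat step

A few compounds are considered here, and "the series" means these few. Any claim that something is new, unique, unknown or untested is made for them only; others in the source may bear on it.

This short series asks how much of each compound a cultured human cell line tolerates, measured in a toxicity assay on THP-1 cells (Homo sapiens) for inhibition; a higher number here means that more compound is tolerated, a lower number that less compound is tolerated. Compound 1 `COc1ccc(-c2cnc(NC(=O)c3ccccc3F)n2C)cc1` gives > 100000 nM, which is a limit of the test rather than a number. Compound 2 `COc1ccc(-c2cnc(NC(=O)c3ccc([N+](=O)[O-])cc3)n2C)cc1` likewise reaches only a limit, > 100000 nM. Compound 3 `Cn1c(-c2ccc(F)cc2)cnc1NC(=O)c1ccc(F)cc1` also gives a limit, > 100000 nM, in this assay. Compound 3 therefore stands exactly where the other two stand, at the edge of what the test can report, since (the limit of > 100000 nM in this assay, at which 3 of the 3 values shown sit).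

Compound 4 `COc1ccc(-c2cnc(NC(=O)c3ccc(F)cc3)n2C)cc1` has not yet been measured. It differs from compound 3 in one place: methoxy in place of fluoro on an aromatic carbon. Within the data shown here, compound 1 and compound 2 already carry a 4-methoxyphenyl, and both sit at the limit, so nothing among the measured compounds points to a shift beyond the scatter in either direction for this assay. The step expected in this assay is a number no higher from compound 3 to compound 4 (the limit leaves the size open), which amounts to no change worth noting. Compound 4 is expected to come out at about 100000 nM, within a range from 50000 nM to 300000 nM, and most likely the test will again report only a limit for compound 4.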

Compound 4, half-maximal cytotoxic concentration: >= 50000 nM
Compound 4 ended at the assay's limit (the forecaster's own chance of this, stated with the estimate: 85%); the middle value is on the limit's open side.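

Among these compounds, compound 1, compound 2, compound 3 and compound 4 all reach only a limit in this assay, so no step to compound 4 can be read from any of them. The compounds shown leave open what concentration of each compound is actually toxic to these cells, and whether any of these changes shifts it.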